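A few compounds are considered here, and "the series" means these few. Any claim that something is new, unique, unknown or untested is made for them only; others in the source may bear on it.

The series rests on a shared core carrying a hydrazone bridge, and two compounds of it have been measured in an assay on mitochondria for inhibition of Amine oxidase [flavin-containing] B (Bos taurus); a higher number here means a weaker inhibitor, a lower number a stronger inhibitor. Compound 1 `Clc1ccc(/C=N/Nc2nc(-c3ccccc3)cs2)cc1` gives 170 nM in this assay. Compound 2 `COc1ccc(/C=N/Nc2nc(C)cs2)cc1` gives 4.07 nM in this assay, the lowest of the two numbers, and the gap to compound 1 lies well beyond the scatter; since the two compounds differ in two places at once, nothing can be said about which of the two differences carries that gap.

Compound 3 `COc1ccc(/C=N/Nc2nc(-c3ccccc3)cs2)cc1` is built from compound 2 by a single change, (phenyl in place of methyl on an aromatic carbon), with the phenyl now standing on an aromatic carbon of a five-membered aromatic ring with 1 nitrogen and 1 sulfur. Going by the values given here, no measured pair isolates this exact change. Among the compounds with values here, the only compound bearing the phenyl there, compound 1, gives 170 nM, a far higher number than compound 2, but its other difference clouds the picture. Compound 3 is therefore expected to show a weakening of modest size, a 4.9-fold higher number from compound 2 to compound 3 (0.69 log units; beyond the scatter), with the estimate for compound 3 being 20 nM and a range from 3 nM to 150 nM.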

Compound 3, inhibition constant: 132 nM
Estimate against measurement, compound 3: 6.6-fold (0.82 log units) below; measured number inside the range.
By their numbers in this assay, from the lowest: compound 2; then compounds 3 and 1 (each within the scatter of the next).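

Taken alone, the change on the aromatic carbon next to the ring nitrogen is a large one: in this assay phenyl in place of methyl gives a 32-fold higher number from compound 2 to compound 3 (1.51 log units; beyond the scatter) and so shows that this position by itself can move the number well beyond the scatter, which the two-place difference of the earlier pair could not show. With phenyl at this position, methoxy in place of chloro gives a 1.3-fold lower number from compound 1 to compound 3 (0.11 log units; within the scatter) and stays within the scatter, so compound 1 and compound 3 cannot be told apart in this assay and no effect of that exchange can be read here. Nothing measured here accounts for the large step at this position.

It remains open whether methoxy and chloro would also stay within the scatter of each other with methyl at this position, since the chloro partner of compound 2 is not among the compounds shown. Also open, going by these compounds, is how the number would respond to other groups on this aromatic carbon, such as an ethyl group, a cyclopropyl ring, an amine or a carboxylic acid.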